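Amide nitrogen change on compound 2

This account rests on a few compounds, and the source may have more. Where it says the series, first, only, none or still open, it means among the compounds named here.

Values in a functional assay on MDA-MB-468 cells (Homo sapiens) for inhibition, read by MTT assay (a higher number here means a weaker inhibitor of growth, a lower number a stronger inhibitor of growth), follow
compound 1 `CC1=C(/C=C/C(C)=C/C=C/C(C)=C\C(=O)Nc2ccc(O)cc2)C(C)(C)CCC1n1ccnc1`: 6830 nM
compound 2 `CC1=C(/C=C/C(C)=C/C=C/C(C)=C\C(=O)NCc2ccc(O)cc2)C(C)(C)CC=C1c1cncnc1`: 19100 nM

Compound 2 at 19100 nM stands highest of the two numbers, and compound 1 lies lower, beyond the scatter. For the measured compounds named here, these two differ in more than one place, so no measured step isolates a single change. Compound 3 `CC1=C(/C=C/C(C)=C/C=C/C(C)=C\C(=O)Nc2ccccc2)C(C)(C)CC=C1c1cncnc1` has phenyl in place of 4-hydroxybenzyl on an amide-type nitrogen. Going by the values given here, compound 1 at 6830 nM is the only lower number available, so only a small fall in this assay is expected, not clearly beyond the scatter. The estimated step runs a 1.6-fold lower number from compound 2 to compound 3 (0.20 log units; within the scatter) (direction expected, size uncertain). The estimate for compound 3 is 12000 nM (expected range 4000 nM to 35000 nM).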

Compound 3, concentration for 50% growth inhibition: 22900 nM
The estimate for compound 3 lay 1.9-fold (0.28 log units) below the measured number; the range from low to high includes it.
By their numbers in this assay, from the lowest: compound 1; then compounds 2 and 3 (each within the scatter of the next).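

In this assay, for the compounds shown here, the change from 4-hydroxybenzyl to phenyl on the amide-type nitrogen gives a 1.2-fold higher number from compound 2 to compound 3 (0.08 log units; within the scatter) within the scatter, the only single-place step. At this position, then, the two groups are not separated, even though phenyl carries no hydrogen-bond donor or acceptor. Nothing measured on these compounds accounts for this result.

Still open, on these data alone, is whether an amine or a carboxylic acid on the phenyl ring would separate from compound 3. A longer chain on the amide-type nitrogen is equally untested here.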